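Notes on replacing fluoro with cyano in compound 2

The compounds below may be only part of what the source reports. "The series", "measured", "known", "first", "only" and "open" are said of these compounds alone.

Three compounds have numbers in a functional assay on the whole organism for positive allosteric modulation, with Mus musculus as the target; on this read-out lower numbers stand for an effect already at smaller amounts and higher numbers for an effect only at larger amounts of compound. Compound 1 `CC(=O)N(c1ccccc1)C1CCCC1N(C)C` gives 7 mg/kg, compound 2 `CCC(=O)N(c1ccc(F)cc1)C1CCCC1N(C)C` gives 5 mg/kg, and compound 3 `CCC(=O)N(c1ccc(F)c(Cl)c1)C1CCCC1N(C)C` gives 0.2 mg/kg. Compound 2 thus lies within the scatter of compound 1, while its number stands well above that of compound 3.

Compound 4 `CCC(=O)N(c1ccc(C#N)cc1)C1CCCC1N(C)C` has not yet been measured in this assay. Its difference from compound 2 is cyano in place of fluoro on an aromatic carbon, para to a large group.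

For the measured compounds named here, only one measured step bears on this change, and only indirectly. The large step of a 25-fold lower number from compound 2 to compound 3 (1.40 log units; beyond the scatter) is beyond the scatter and comes from chloro in place of hydrogen on an aromatic carbon. Going by the values given here, it shows that the number can respond strongly to a change on this ring, but no measured step removes the fluoro, so the data set no direction. The expected outcome is a 1.4-fold higher number from compound 2 to compound 4 (0.15 log units; within the scatter), a step not expected to leave the scatter. For compound 4 the estimated value is 7 mg/kg, with an expected range of 2 mg/kg to 25 mg/kg.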

Compound 4, dose for half-maximal effect: 10 mg/kg
Compound 4: middle estimate off by 1.4-fold (0.15 log units), on the low side; measured number inside the range.
By their numbers in this assay, from the lowest: compound 3; then compounds 2, 1 and 4 (each within the scatter of the next).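

In this assay the exchange of fluoro for cyano on this aromatic carbon, para to a large group, gives a 2.0-fold higher number from compound 2 to compound 4 (0.30 log units; within the scatter) and so leaves compound 4 within the scatter of compound 2. At this place, then, a group of 2 heavy atoms with 1 hydrogen-bond acceptor and a group of 1 heavy atom with 0 hydrogen-bond acceptors cannot be told apart by this read-out, and the exchange shows nothing like the large step of a 25-fold lower number from compound 2 to compound 3 (1.40 log units; beyond the scatter). Nothing available gives a reason for this result.

On these data alone, whether an amine, a carboxylic acid or a methoxy group on this carbon would also stay within the scatter remains open. Also open, as far as these compounds go, is whether the chloro of compound 3 would give a step of similar size alongside cyano.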